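Swapping an Aromatic Ring for a Non-Aromatic One on the Core

The compounds below may be only part of what the source reports. "The series", "measured", "known", "first", "only" and "open" are said of these compounds alone.

Of the compounds shown here, two sharing the same fused core have been measured in an assay on isolated protein for binding affinity to Alpha-1A adrenergic receptor (Rattus norvegicus), read by radioligand binding; on this read-out higher numbers stand for weaker inhibition and lower numbers for stronger inhibition. Compound 1 `CCCS(=O)(=O)Nc1cccc2c1CCCC2c1c[nH]cn1` gives 1700 nM in this assay. Compound 2 `Cn1cnc(C2CCCc3c(NS(C)(=O)=O)cccc32)c1` gives 275 nM in this assay, the lower of the two numbers, and the gap to compound 1 lies beyond the usual scatter, so compound 2 binds more tightly than compound 1. Within the data shown here, the two compounds differ in more than one place, so no single structural step links them.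

Compound 3 `CS(=O)(=O)Nc1cccc2c1CCCC2C1=NCCN1` has not yet been measured. It differs from compound 2 in one place only: a group of 5 heavy atoms (3 carbon, 2 nitrogen; one five-membered non-aromatic ring with 2 hetero atoms) in place of a group of 6 heavy atoms (4 carbon, 2 nitrogen; one five-membered aromatic ring with 2 hetero atoms), on a saturated ring carbon. The group that leaves is the 1-methyl-1H-imidazol-4-yl group; the group that enters has no common name and is a five-membered non-aromatic ring with 2 hetero atoms, sitting on the same saturated ring carbon.

Among the measured compounds shown here, no measured pair shows the effect of this change, so the expectation is uncertain. The step of a 4.6-fold lower number from compound 2 to compound 3 (0.66 log units; beyond the scatter) is expected to be downward, a moderate step beyond the scatter. Compound 3 is estimated at 60 nM in this assay, within a range from 10 nM to 400 nM.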

Compound 3, inhibition constant: 457 nM
Compound 3: middle estimate off by 7.6-fold (0.88 log units), on the low side; the measured number lies above the stated range.
By their numbers in this assay, from the lowest: compounds 2 and 3 (each within the scatter of the next); then compound 1.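

In this assay, placing the five-membered non-aromatic ring on the saturated ring carbon in place of the 1-methyl-1H-imidazol-4-yl group gives a 1.7-fold higher number from compound 2 to compound 3 (0.22 log units; within the scatter) and so leaves the two compounds indistinguishable on this read-out. This is the first single-place change shown at this position, and it indicates that binding here does not depend on keeping an aromatic ring, at least for this one replacement, even though the entering group has 1 hydrogen-bond donor and the leaving group has 0. No measurement available here accounts for the two groups performing alike.

The compounds shown leave open how far this tolerance extends, for instance whether an open-chain amine or a carboxylic acid on the same saturated ring carbon would keep the number in the same range. Compound 1 differs from compound 2 and from compound 3 in more than one place, so the separate contributions of its propyl chain and its ring cannot be read from these data.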